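The source may report more compounds than this note shows. Statements on the series, on what has been measured and on what is new or still open speak of the compounds shown alone.

Series notes. In a functional assay on HepG2 cells (Homo sapiens) for cytotoxicity, read by MTT assay, with a stated time of 72 h (a lower number here means a stronger inhibitor, a higher number a weaker inhibitor), compound 1 `O=C(Nc1ccc(Oc2ccnc3[nH]ccc23)cc1)c1nn(-c2ccc(Cl)cc2)ccc1=O` gives 19500 nM. Compound 3 `Cn1ccc2c(Oc3ccc(NC(=O)c4nn(-c5ccc(Cl)cc5)ccc4=O)cc3)ccnc21`, which carries a methyl in place of hydrogen on an aromatic nitrogen, reaches only the limit of the assay, > 60000 nM. Thus an at least 3.0-fold higher number from compound 1 to compound 3 (0.48 log units; beyond the scatter). Compound 2 `COc1ccc(-n2ccc(=O)c(C(=O)Nc3ccc(Oc4ccnc5[nH]ccc45)c(F)c3)n2)cc1` likewise sits at a limit, > 60000 nM. Compound 3 therefore stands at the weak end of the numbers shown, sharing the limit of > 60000 nM in this assay, at which 2 of the 3 values shown sit, with compound 2.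

Compound 4 `Cn1ccc2c(Oc3ccc(NC(=O)c4nn(-c5ccc(Br)cc5F)ccc4=O)cc3)ccnc21` differs from compound 3 by 4-bromo-2-fluorophenyl in place of 4-chlorophenyl on an aromatic nitrogen. Within the data shown here, no measured pair varies this phenyl ring alone, so no measured step bears directly on the change; the only measured step, an at least 3.0-fold higher number from compound 1 to compound 3 (0.48 log units; beyond the scatter), concerns the methyl on the aromatic nitrogen. Compound 3 gives a limit and not a number, so the size of a step from it cannot be read. The expectation is that compound 4 also yields no number, which means a step that the limit leaves unreadable from compound 3 to compound 4. Compound 4 is expected at 80000 nM, with a range from 20000 nM to 300000 nM, most likely reported as a limit.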

Compound 4, half-maximal inhibitory concentration: 31200 nM
For compound 4 the middle estimate is 2.6-fold (0.41 log units) above the measured one; the range from low to high includes it.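

The phenyl ring on the aromatic nitrogen is a place where a change can turn a limit into a measured number in this assay, with an at least 1.9-fold lower number from compound 3 to compound 4 (0.28 log units; that floor lies within the scatter). Among these compounds, compound 4 keeps the methyl on the aromatic nitrogen, so that methyl does not by itself hold a compound at a limit, which the earlier compounds could not show. Limits nevertheless remain frequent in this small set: the limit of > 60000 nM in this assay, at which 2 of the 4 values shown sit.

The change from 4-chlorophenyl to 4-bromo-2-fluorophenyl replaces chlorine with bromine and adds fluorine in one step, so the compounds shown do not separate the two halogens. Also open, as far as these compounds go, is how this ring responds to a group of another kind, such as an amine or a carboxylic acid in place of the halogen.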